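The source may hold more compounds than are shown below. What is called first, only, known or untested is meant among the compounds shown, and "the series" means these compounds.

In a functional assay on cells for antagonist activity at C-X-C chemokine receptor type 4 (Homo sapiens), read by fluorescence and calcium flux, with stated times of 25 min and 90 s (a lower number here means a stronger inhibitor, a higher number a weaker inhibitor), compound 1 `c1ccc(CN(CCCCN(C[C@H]2Cc3ccccc3CN2)[C@H]2CCCc3cccnc32)Cc2ccccn2)nc1` gives 664 nM, compound 2 `c1ccc2c(c1)CN[C@@H](CN(CCCCNCC1CCCCC1)[C@H]1CCCc3cccnc31)C2` gives 158 nM, and compound 3 `c1ccc2c(c1)CN[C@@H](CN(CCCCNCC1CCNCC1)[C@H]1CCCc3cccnc31)C2` gives 36.5 nM. Among these three numbers compound 3 stands lowest, and its distances to compound 2 and to compound 1 are both beyond the usual scatter. For the measured compounds named here, the only measured step between close neighbours is a 4.3-fold lower number from compound 2 to compound 3 (0.64 log units; beyond the scatter), where the change was piperidin-4-yl in place of cyclohexyl on a saturated chain carbon bound to an amine nitrogen. Compound 4 `c1ccc2c(c1)CN[C@@H](CN(CCCCNC1CCNCC1)[C@H]1CCCc3cccnc31)C2` differs from compound 3 by piperidin-4-yl in place of (piperidin-4-yl)methyl on an amine nitrogen; the ring itself stays, and only the chain carbon that joined it to the amine nitrogen is gone. Going by the values given here, no measured step covers this kind of change, so that single step is no guide to its size, and nothing in the data points in a direction beyond the scatter. Compound 4 is therefore expected to give about 45 nM, within 12 nM to 160 nM, which is an expected step of a 1.2-fold higher number from compound 3 to compound 4 (0.09 log units; within the scatter).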

Compound 4, half-maximal inhibitory concentration: 63.4 nM
For compound 4 the middle estimate is 1.4-fold (0.15 log units) below the measured one; low and high end bracket the measured number.
By their numbers in this assay, from the lowest: compounds 3 and 4 (each within the scatter of the next); then compound 2; then compound 1.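

In this assay taking out the chain carbon that joined the ring to the amine nitrogen gives a 1.7-fold higher number from compound 3 to compound 4 (0.24 log units; within the scatter) and so makes no difference the scatter can separate: this amine nitrogen accepts piperidin-4-yl as well as (piperidin-4-yl)methyl. Putting piperidin-4-yl in place of cyclohexylmethyl gives a 2.5-fold lower number from compound 2 to compound 4 (0.40 log units; beyond the scatter) and shows that the lower number seen with the nitrogen-containing ring in compound 3 also holds in compound 4, without the chain carbon. No evidence is available to explain these numbers.

Still open, from the compounds shown here alone, is whether a cyclohexyl group bound directly to the amine nitrogen would match compound 2 or compound 4, which would separate the role of the ring nitrogen from that of the chain carbon. Also open, going by these compounds, is how a longer chain, as in 2-(piperidin-4-yl)ethyl, would read.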